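The source may report more compounds than this note shows. Statements on the series, on what has been measured and on what is new or still open speak of the compounds shown alone.

Working notes on the series: compound 1 `Nc1nc(N)c2c(-c3cccs3)cn([C@@H]3O[C@H](CO)[C@@H](O)[C@H]3O)c2n1`, compound 2 `COc1nc(N)nc2c1c(-c1ccoc1)cn2[C@@H]1O[C@H](CO)[C@@H](O)[C@H]1O` and the unmeasured compound 3 `COc1nc(N)nc2c1c(-c1cccs1)cn2[C@@H]1O[C@H](CO)[C@@H](O)[C@H]1O` all belong to an ADME assay on MRC5 cells (Homo sapiens), read by MTT assay, with a stated time of 72 h; a higher number here means a weaker inhibitor, a lower number a stronger inhibitor. Compound 1 gives > 100000 nM, which is a limit of the assay and not a number. Compound 2 gives > 100000 nM, again a limit and not a number. Compound 2 therefore has no exact place in the series, and the only reference point is the limit of > 100000 nM in this assay, at which 2 of the 2 values shown sit.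

The change from compound 2 to compound 3 is thiophen-2-yl in place of furan-3-yl on an aromatic carbon. Compound 1 already carries thiophen-2-yl at this place and gives > 100000 nM, which is also a limit. Going by the values given here, no measured step between compounds differing in one place is available, so the expectation rests on that limit alone. No step beyond the scatter is expected in this assay, and no direction is favoured. Expressed as an estimate, this is a number no higher from compound 2 to compound 3 (the limit leaves the size open). The estimate for compound 3 is 100000 nM, with an expected range of 40000 nM to 200000 nM.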

Compound 3, half-maximal inhibitory concentration: > 100000 nM
Compound 3 was reported as a limit; the forecaster's own chance of this, stated with the estimate: 85%; the middle value lies on the limit itself.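

In this assay compound 3 gives > 100000 nM, a limit of the assay and not a number. No new step can be read between compound 3 and compound 1 or compound 2 because all three rest on the same limit: the limit of > 100000 nM in this assay, at which 3 of the 3 values shown sit.

The compounds shown leave open whether thiophen-2-yl in place of furan-3-yl, or methoxy in place of amino, changes the read-out at all.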